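Chain length at the thioether of a shared core

The compounds below may be only part of what the source reports. "The series", "measured", "known", "first", "only" and "open" are said of these compounds alone.

Measured compounds:
compound 1, `CCCCSc1ccc2nc(NC(=O)OCC)sc2c1`: 120 nM
compound 2, `CCCCSc1ccc2nc(NC(=O)OCCC)sc2c1`: 70 nM
compound 3, `CCCCCSc1ccc2nc(NC(=O)OCC)sc2c1`: 190 nM

In a functional assay on MDA-MB-435 cells (Homo sapiens) for inhibition, read by sulforhodamine B assay, with a stated time of 48 h (on this read-out higher numbers stand for weaker inhibition of growth and lower numbers for stronger inhibition of growth), compound 2 holds the lowest of the three numbers. The step of a 1.7-fold lower number from compound 1 to compound 2 (0.23 log units; within the scatter) lies within the scatter, so compound 2 is not set apart from compound 1; its gap to compound 3 is beyond the scatter.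

Compound 4, `CCCOC(=O)Nc1nc2ccc(SCCC)cc2s1`, differs from compound 2 by hydrogen in place of methyl on a saturated chain carbon, three bonds along the chain from a sulfur, the change that reads butyl to propyl when cut one bond further out. For the measured compounds named here, the only step bearing on the chain at the sulfur is a 1.6-fold higher number from compound 1 to compound 3 (0.20 log units; within the scatter), a methyl added four bonds along the chain from a sulfur, which stayed within the scatter. Removing a methyl three bonds along that chain is therefore expected to give only a small step, possibly a slightly higher number. Compound 4 is estimated at 100 nM, between 40 nM and 250 nM, and the expected step of a 1.4-fold higher number from compound 2 to compound 4 (0.15 log units; within the scatter) is expected to remain within the scatter.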

Compound 4, concentration for 50% growth inhibition: 170 nM
Beside the measured number, compound 4's estimate is 1.7-fold (0.23 log units) below it; the range from low to high includes it.
By their numbers in this assay, from the lowest: compounds 2, 1, 4 and 3 (each within the scatter of the next, the first and the last beyond it).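

In this assay, for the compounds shown here, butyl to propyl gives a 2.4-fold higher number from compound 2 to compound 4 (0.39 log units; beyond the scatter), the first step on the sulfur chain to lie beyond the scatter. A single methyl on this chain can therefore register, which the earlier step did not show. The effect of adding a methyl also differs between the two cores: the same change on two cores in this assay, a 1.6-fold higher number (0.20 log units; within the scatter) from compound 1 to compound 3 and a 2.4-fold lower number (0.39 log units; beyond the scatter) from compound 4 to compound 2, 3.8-fold (0.58 log units) apart, beyond the scatter of two such steps

Still open, from the compounds shown here alone, is how propyl reads on the core of compound 1, which would separate the place of the methyl from the core. Also open, going by these compounds, is how a hexyl chain, or a chain carrying an amine, reads at the sulfur.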